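The compounds below may be only part of what the source reports. "The series", "measured", "known", "first", "only" and "open" are said of these compounds alone.

Compound 1 `CC(C)[C@H](NC(=O)CN(c1nc(Cl)nc2[nH]cnc12)C1CC1)C(=O)OCc1ccccc1` gives 27.3% in a functional assay on the whole organism (Tail, strain ICR) with Mus musculus as the target, in the tail flick test, with a stated time of 120 min, at a dose of 25 umol/kg by the oral route; a higher number here means a stronger effect of the compound at the dose given, a lower number a weaker effect.
Compound 2 `O=C(CN(c1nc(Cl)nc2[nH]cnc12)C1CC1)N[C@@H](CCC(=O)OCc1ccccc1)C(=O)OCc1ccccc1` gives 45.9% in this assay.
Compound 3 `NCCCC[C@H](NC(=O)CN(c1nc(Cl)nc2[nH]cnc12)C1CC1)C(=O)OCc1ccccc1` gives 16.8% in this assay.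

Compound 3 stands lowest of the three measured numbers. Its nearest neighbour is compound 1, and the step of a number 10.5 percentage points lower from compound 1 to compound 3 (beyond the scatter) lies beyond the scatter; the step of a number 29.1 percentage points lower from compound 2 to compound 3 (beyond the scatter) is larger still. The unmeasured compound 4 `CC[C@H](C)[C@H](NC(=O)CN(c1nc(Cl)nc2[nH]cnc12)C1CC1)C(=O)OCc1ccccc1` differs from compound 3 in one place: sec-butyl in place of 4-aminobutyl on a saturated chain carbon bound to an amide-type nitrogen and a carbonyl carbon. Among the compounds with values here, the only measured step that bears directly on this exchange is the one that introduced the departing group, a number 10.5 percentage points lower from compound 1 to compound 3 (beyond the scatter), where isopropyl gave way to 4-aminobutyl on the same saturated chain carbon. Sec-butyl resembles isopropyl more closely than it does 4-aminobutyl, so the reverse of that step, a modest rise, is the natural expectation. The step of a number 18.6 percentage points higher from compound 1 to compound 2 (beyond the scatter) concerns 2-(benzyloxycarbonyl)ethyl and does not speak to a sec-butyl group, so it is left aside. Compound 4 is therefore expected to land near the number of compound 1, a rise of about a number 11.2 percentage points higher from compound 3 to compound 4 (beyond the scatter) over compound 3, beyond the scatter but modest. The estimate for compound 4 in this assay is 28%, within a range from 15% to 41%.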

Compound 4, a percentage reported as activity, at one dose (the size of the read-out at that dose, not a potency): 22%
Beside the measured number, compound 4's estimate is 6 percentage points above it; the measured number falls inside the stated range.
By their numbers in this assay, from the lowest: compounds 3, 4 and 1 (each within the scatter of the next, the first and the last beyond it); then compound 2.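

At the saturated chain carbon bound to an amide-type nitrogen and a carbonyl carbon, the exchange of 4-aminobutyl for sec-butyl gives a number 5.2 percentage points higher from compound 3 to compound 4 (within the scatter) in this assay, so this change does not separate the two groups, even though isopropyl and 4-aminobutyl were separated beyond the scatter in compounds 1 and 3. The added methyl in place of hydrogen, three bonds along the chain, gives a number 5.3 percentage points lower from compound 1 to compound 4 (within the scatter), so isopropyl and sec-butyl cannot be told apart here, and compound 4 lies within the scatter of both compound 1 and compound 3. By contrast, sec-butyl in place of 2-(benzyloxycarbonyl)ethyl gives a number 23.9 percentage points lower from compound 2 to compound 4 (beyond the scatter), which confirms that compound 2 stands apart, since its steps to all three other compounds are printed as beyond the scatter.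

Nothing at hand explains any of these numbers. On these data alone, it remains open whether a carboxylic acid in place of the benzyloxycarbonyl on that chain, or a longer chain ending in benzyloxycarbonyl, would keep the number of compound 2, and whether a simple benzyl group at this carbon would fall with the alkyl groups or with compound 2.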